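The source may report more compounds than this note shows. Statements on the series, on what has been measured and on what is new or still open speak of the compounds shown alone.

Compound 1 `CCOCCOc1cccc2ccc(N)nc12` and compound 2 `CC(CC(C)(C)C)Oc1cccc2ccc(N3CCCCC3)nc12` share the same core and were both tested in an assay on cells with melanin-concentrating hormone receptor 1 (Homo sapiens) as the target, read by radioligand binding; on this read-out higher numbers stand for weaker inhibition and lower numbers for stronger inhibition. Compound 1 gives > 2000 nM in this assay, which is a limit of the assay rather than a number. Compound 2 likewise gives > 2000 nM in this assay, again only a limit. Compound 1 therefore stands at the limit of > 2000 nM in this assay, at which 2 of the 2 values shown sit, so no measured number sets it apart from any other compound. Compound 3 `Nc1ccc2cccc(OCC3CC3)c2n1` has not yet been measured in this assay. It differs from compound 1 by cyclopropyl in place of ethoxymethyl on a saturated chain carbon bound to an oxygen on an aromatic ring. Among the measured compounds shown here, no measured pair shows how such a change acts here, so the step is expected to be small, with none beyond the usual scatter in this assay. The expected step is a step that the limit leaves unreadable from compound 1 to compound 3. Compound 3 is expected to give about 3000 nM in this assay, within a range from 800 nM to 15000 nM.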

Compound 3, half-maximal inhibitory concentration: > 2000 nM
Compound 3 gave a limit, no number; the forecaster's own chance of this, stated with the estimate: 65%; the middle value lies beyond the limit too.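

Compound 3 gives > 2000 nM in this assay, which is a limit and not a number. Among the compounds shown here, compound 1 also stands at a limit, so no step from compound 1 to compound 3 can be read. The compounds shown leave open which change to the shared core, if any, would give a measurable number: the limit of > 2000 nM in this assay, at which 3 of the 3 values shown sit.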